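Three Sulfonamides at the Limit and a Dichlorophenyl Successor

The source may hold more compounds than are shown below. What is called first, only, known or untested is meant among the compounds shown, and "the series" means these compounds.

Compound 1 `O=S(=O)(Nc1ccc(-c2nc3ccccc3o2)cc1)c1cccs1`: in an assay on isolated protein for inhibition of malate dehydrogenase, mitochondrial (Sus scrofa), with stated times of 45 min and 30 min (a lower number here means a stronger inhibitor, a higher number a weaker inhibitor), compound 1 gives only the limit > 63000 nM.
Compound 2 `O=S(=O)(Nc1ccc(-c2nc3ccccc3o2)cc1)c1ccc(F)c(C(F)(F)F)c1`: in this assay compound 2 gives only the limit > 63000 nM.
Compound 3 `O=S(=O)(Nc1ccc2oc(-c3ccccc3)nc2c1)c1ccccc1O`: in this assay compound 3 gives only the limit > 63000 nM.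

None of the three measured compounds yields a number; each stops at the same limit, and compound 3 stands exactly where the other two stand, with no number of its own. The shared picture is summed up in the limit of > 63000 nM in this assay, at which 3 of the 3 values shown sit.

Compound 4 `O=S(=O)(Nc1ccc2oc(-c3ccccc3)nc2c1)c1ccc(Cl)c(Cl)c1` is the unmeasured partner of compound 3. The change is 3,4-dichlorophenyl in place of 2-hydroxyphenyl on a sulfonyl sulfur. Among the compounds with values here, no pair of measured compounds differs in a single place, so no measured step shows how such a swap of the group on the sulfonyl sulfur moves the read-out. Because all three measured compounds sit at the limit (the limit of > 63000 nM in this assay, at which 3 of the 3 values shown sit), no step beyond the scatter is expected, in either direction, for this assay.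

For compound 4 the expected value is 80000 nM, between 20000 nM and 300000 nM, and the expected step is a step that the limit leaves unreadable from compound 3 to compound 4; most likely this assay again reports only a limit for compound 4.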

Compound 4, half-maximal inhibitory concentration: > 63000 nM
Compound 4 was reported as a limit; the forecaster's own chance of this, stated with the estimate: 80%; the middle value is on the limit's open side.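

No step can be read from compound 3 to compound 4, because each gives only a limit and no number: the limit of > 63000 nM in this assay, at which 4 of the 4 values shown sit.
The compounds shown leave open whether any group on the sulfonyl sulfur would give an actual number rather than a limit.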